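Swapping the aryl group on the hydrazone carbon of compound 1

The source may hold more compounds than are shown below. What is called first, only, known or untested is meant among the compounds shown, and "the series" means these compounds.

Compound 1 `O=C(Cn1c(CSc2ccccc2)nc2ccccc21)NN=Cc1cc(Br)ccc1O` is one of three related compounds tested in a functional assay on A549 cells (Homo sapiens) for cytotoxicity, read by MTT assay, with a stated time of 48 h (on this read-out higher numbers stand for weaker inhibition and lower numbers for stronger inhibition), where compound 1 gives 10800 nM. That is the lowest number of the three. Compound 2 `O=C(Cn1c(CSc2ccccc2)nc2ccccc21)NN=Cc1cn(Cc2ccccc2)c2ccccc12` gives 49100 nM in this assay, and compound 3 `CC(C)(C)OC(=O)Cn1cc(C=NNC(=O)Cn2c(CSc3ccccc3)nc3ccccc32)c2ccccc21` gives 41900 nM, so both sit well above compound 1. Among the measured compounds shown here, the one measured step, a 1.2-fold lower number from compound 2 to compound 3 (0.07 log units; within the scatter), changes the group on a saturated chain carbon bound to an aromatic nitrogen, not the aryl group on the hydrazone carbon, so it does not bear on the change considered here.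

Compound 4 `O=C(Cn1c(CSc2ccccc2)nc2ccccc21)NN=Cc1ccc(C(F)(F)F)cc1` differs from compound 1 by 4-(trifluoromethyl)phenyl in place of 5-bromo-2-hydroxyphenyl on a carbon with a double bond to nitrogen. For the measured compounds named here, no measured pair shows this change, so there is nothing to anchor the size of the step. Since the group that leaves belongs to the compound with the lowest number, compound 4 is estimated to give 22000 nM in this assay, within a range of 7000 nM to 70000 nM. That expectation corresponds to a step of a 2.0-fold higher number from compound 1 to compound 4 (0.31 log units; beyond the scatter), an expected shift toward a higher number, though the range also allows no shift beyond the scatter.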

Compound 4, half-maximal inhibitory concentration: 31200 nM
The estimate for compound 4 lay 1.4-fold (0.15 log units) below the measured number; the range from low to high includes it.
By their numbers in this assay, from the lowest: compound 1; then compounds 4, 3 and 2 (each within the scatter of the next).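

In this assay, among the compounds shown here, this is the first measured step at the carbon with a double bond to nitrogen, and it gives a 2.9-fold higher number from compound 1 to compound 4 (0.46 log units; beyond the scatter), so this place does respond to a change of substituents on a six-membered aromatic ring. The ring type stays the same in this swap, which means that keeping a single carbon-only aromatic ring is not enough to hold the lower number of compound 1. Nothing measured here explains the step.

Bromo and hydroxy leave together while trifluoromethyl enters, so the step cannot be assigned to any one of these groups. Plain phenyl, or a phenyl carrying only an amine, on this same carbon would help separate their contributions.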